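The compounds below may be only part of what the source reports. "The series", "measured", "known", "first", "only" and "open" are said of these compounds alone.

Working notes on the series. Compound 1 `CC(C)n1cnc2c(N(C)C)ncnc21` and compound 2 `CCC(C)n1cnc2c(N(C)C)ncnc21` share one core; compound 3 `CCOc1nc(NC2CC2)c2ncn(CC3CC3)c2n1` is built on another core, and the difference between the two cores is not broken down here. In a functional assay on the whole organism for antagonist activity, with Rattus norvegicus as the target (on this read-out higher numbers stand for an effect only at larger amounts of compound and lower numbers for an effect already at smaller amounts), compound 1 gives 11 mg/kg and compound 2 gives 14 mg/kg. The change between them is methyl in place of hydrogen on a saturated chain carbon, two bonds along the chain from an aromatic nitrogen, and the step it made is a 1.3-fold higher number from compound 1 to compound 2 (0.10 log units; within the scatter). In this assay compound 3 gives 0.8 mg/kg, the lowest of the three numbers. Compound 4 `CCCOc1nc(NC2CC2)c2ncn(CC3CC3)c2n1` has not been measured; it differs from compound 3 by methyl in place of hydrogen on a saturated chain carbon, two bonds along the chain from an oxygen on an aromatic ring. This is the same kind of change as that between compound 1 and compound 2, but the place differs: in the measured pair the saturated chain carbon lies two bonds along the chain from an aromatic nitrogen, here two bonds along the chain from an oxygen on an aromatic ring. Among the measured compounds shown here, the expectation rests on the one measured example of this kind of change, which stayed within the scatter. For compound 4 in this assay the expected step is a 1.3-fold higher number from compound 3 to compound 4 (0.10 log units; within the scatter). Compound 4 is estimated at 1 mg/kg, with a range from 0.5 mg/kg to 2 mg/kg.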

Compound 4, dose for half-maximal effect: 2.5 mg/kg
Estimate against measurement, compound 4: 2.5-fold (0.40 log units) below, outside the stated range (above it).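

In this assay, methyl in place of hydrogen on a saturated chain carbon, two bonds along the chain from an oxygen on an aromatic ring, gives a 3.1-fold higher number from compound 3 to compound 4 (0.49 log units; beyond the scatter). Both measured examples of this change go the same way, and although only the newer step lies beyond the scatter, the two steps cannot be told apart: the same change on two cores in this assay, a 1.3-fold higher number (0.10 log units; within the scatter) from compound 1 to compound 2 and a 3.1-fold higher number (0.49 log units; beyond the scatter) from compound 3 to compound 4, 2.5-fold (0.39 log units) apart, within the scatter of two such steps. Among the compounds shown here, this does not show that the change carries over unaltered, nor that the core alters its effect: with only two pairs, which differ both in core and in the place of the methyl, the contribution of core and place cannot be separated, and a real difference of modest size would not be excluded.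

The compounds shown leave open how the number moves when the chain on the oxygen grows beyond propoxy, for instance to butoxy, and whether a branched chain such as isopropoxy follows the same course. They also leave open what an amine in place of the ethoxy group on the core of compound 3 would give.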